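The source may report more compounds than this note shows. Statements on the series, on what has been measured and on what is new or still open speak of the compounds shown alone.

In a functional assay on A549 cells (Homo sapiens) for antiproliferative activity, read by MTT assay, with a stated time of 72 h (a higher number here means a weaker inhibitor, a lower number a stronger inhibitor), compound 1 `O=C(N/N=C/c1ccccc1)Nc1ccc(Oc2ccnc3[nH]ccc23)c(F)c1` gives (2500 nM) and compound 2 `O=C(N/N=C/c1cccc([N+](=O)[O-])c1)Nc1ccc(Oc2ccnc3[nH]ccc23)c(F)c1` gives (3640 nM). Among the compounds with values here, the only measured step, nitro in place of hydrogen on an aromatic carbon, is small (a 1.5-fold higher number from compound 1 to compound 2 (0.16 log units; within the scatter)). Within the data shown here, compound 3 `O=C(N/N=C/c1cccc(Cl)c1Cl)Nc1ccc(Oc2ccnc3[nH]ccc23)c(F)c1` has no number and is reported as ("not active" (no number reported)), so no step can be measured from it. Compound 4 `O=C(N/N=C/c1ccc(Cl)c(Cl)c1)Nc1ccc(Oc2ccnc3[nH]ccc23)c(F)c1` has the same atoms as compound 3, joined differently 3,4-dichlorophenyl in place of 2,3-dichlorophenyl on a carbon with a double bond to nitrogen. Among the measured compounds shown here, no measured step moves a chlorine, so the nitro step is only a loose guide and no step size can be expected from compound 3. A number near those of the measured compounds seems likeliest, though a second "not active" result remains possible. The expected value for compound 4 is about 3500 nM, with an estimated range of 1000 nM to 12000 nM.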

Compound 4, half-maximal inhibitory concentration: 2650 nM
The estimate for compound 4 lay 1.3-fold (0.12 log units) above the measured number, and the stated range covers the measured number.
By their numbers in this assay, from the lowest: compounds 1, 4 and 2 (each within the scatter of the next).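

In this assay, a phenyl ring carrying two chlorines as 3,4-dichlorophenyl gives a number in the same range as the plain phenyl and 3-nitrophenyl rings (a 1.1-fold higher number from compound 1 to compound 4 (0.03 log units; within the scatter); a 1.4-fold lower number from compound 2 to compound 4 (0.14 log units; within the scatter)). So this position can hold both chlorines, while compound 3, with the same atoms as 2,3-dichlorophenyl, is reported as not active, and that change cannot be read as a step because compound 3 has no number. No measurement here accounts for this difference. On these data alone, whether a single chlorine, an amine or a carboxylic acid on this ring would give a similar number remains open.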